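Nitro in place of isopropyl on compound 2: cytotoxicity outlook

A few compounds are considered here, and "the series" means these few. Any claim that something is new, unique, unknown or untested is made for them only; others in the source may bear on it.

The series shares one core, seen in compound 1 `O=[N+]([O-])c1cccc(NC(=S)OCCc2ccccn2)c1`, compound 2 `CC(C)c1ccc(NC(=S)OCCc2ccccn2)cc1` and compound 3 `FC(F)(F)c1ccc(NC(=S)OCCc2ccccn2)cc1`. In an ADME assay on MT4 cells (Homo sapiens) for cytotoxicity, read by MTT assay (on this read-out higher numbers stand for lower toxicity in this test and lower numbers for higher toxicity in this test), compound 1 gives 100000 nM, compound 2 gives 45000 nM and compound 3 gives 50000 nM. Compound 2 and compound 3 lie within the scatter of one another, as the step of a 1.1-fold higher number from compound 2 to compound 3 (0.05 log units; within the scatter) shows; compound 1 stands apart from compound 2, beyond the scatter, with the higher number of the two.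

The next compound is compound 4 `O=[N+]([O-])c1ccc(NC(=S)OCCc2ccccn2)cc1`, which differs from compound 2 in one place: nitro in place of isopropyl on an aromatic carbon. Among the measured compounds shown here, no measured step covers exactly this change. The step of a 1.1-fold higher number from compound 2 to compound 3 (0.05 log units; within the scatter) bears on it only in that a group is exchanged at the same aromatic carbon and no shift beyond the scatter followed. For the measured compounds named here, compound 1 carries a nitro group and its value of 100000 nM in this assay is the only number for a nitro-bearing member. On that basis a step upward is expected for compound 4, roughly a 1.8-fold higher number from compound 2 to compound 4 (0.25 log units; within the scatter) in size, so that compound 4 is estimated at 80000 nM with a range from 35000 nM to 160000 nM.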

Compound 4, half-maximal cytotoxic concentration: > 100000 nM
Compound 4 was reported as a limit; the forecaster's own chance of this, stated with the estimate: 15%; middle value at least 1.2-fold (0.09 log units) away from the limit.
By their numbers in this assay, from the lowest: compounds 2, 3 and 1 (each within the scatter of the next, the first and the last beyond it).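

In this assay compound 4 gives > 100000 nM, which is a limit and not a number. On an aromatic carbon para to a large group, nitro is the only exchange shown that moves the number beyond the scatter, towards lower toxicity in this test, with an at least 2.2-fold higher number from compound 2 to compound 4 (0.34 log units; beyond the scatter), whereas trifluoromethyl in place of isopropyl stays within it, with a 1.1-fold higher number from compound 2 to compound 3 (0.05 log units; within the scatter). The reading against trifluoromethyl is weaker, with an at least 2.0-fold higher number from compound 3 to compound 4 (0.30 log units; that floor lies within the scatter), and the true size of both new steps stays open: the limit of > 100000 nM in this assay, at which 1 of the 4 values shown sits.

Going by these compounds, it remains open whether an amine or a carboxylic acid on this aromatic carbon would track with nitro or with isopropyl and trifluoromethyl in this assay. Also open, on these data alone, is whether a longer chain at this carbon would shift the number beyond the scatter.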